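Halogen swap on the pendant phenyl: bromo to fluoro

The source may hold more compounds than are shown below. What is called first, only, known or untested is meant among the compounds shown, and "the series" means these compounds.

Measured compounds:
compound 1, `COc1ccccc1/C=C1\NS(=O)(=O)c2ccccc2C1=O`, 1240 nM
compound 2, `COc1ccc(/C=C2\NS(=O)(=O)c3ccccc3C2=O)cc1`, 1530 nM
compound 3, `O=C1/C(=C/c2cccc(Br)c2)NS(=O)(=O)c2ccccc21`, 2550 nM

In an assay for inhibition of Intestinal-type alkaline phosphatase (Homo sapiens), read by spectrophotometry, with stated times of 10 min and 20 min (a lower number here means a stronger inhibitor, a higher number a weaker inhibitor), compound 3 gives the highest of the three numbers. Its nearest neighbour is compound 2, whose value lies within the scatter of it; compound 1 stands somewhat further off, and that gap reaches beyond the scatter. Compound 4, `O=C1/C(=C/c2cccc(F)c2)NS(=O)(=O)c2ccccc21`, has not yet been measured. It differs from compound 3 in one place: fluoro in place of bromo on an aromatic carbon, that is, 3-bromophenyl becomes 3-fluorophenyl. Among the compounds with values here, no measured pair in this set shows what such a halogen swap does here. The writer expects a step of a 1.3-fold higher number from compound 3 to compound 4 (0.10 log units; within the scatter), a slight rise in the number, not beyond the scatter. Compound 4 is estimated at 3200 nM, with a range from 1300 nM to 8000 nM.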

Compound 4, half-maximal inhibitory concentration: 9930 nM
The estimate for compound 4 lay 3.1-fold (0.49 log units) below the measured number, outside the stated range (above it).
By their numbers in this assay, from the lowest: compounds 1, 2 and 3 (each within the scatter of the next, the first and the last beyond it); then compound 4.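

In this assay, within the data shown here, fluoro in place of bromo on this aromatic carbon gives a 3.9-fold higher number from compound 3 to compound 4 (0.59 log units; beyond the scatter) and so shows that the two halogens are not interchangeable at this place, which the earlier compounds, with no single-place pair among them, could not show. Bromo carries the lower number of this pair, but one pair sets no trend across the halogens. Nothing available accounts for the difference between the two halogens. On these data alone, whether chloro or iodo at this same place would fall in line with this pair stays open, as does the effect of an amine or a carboxylic acid there.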